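Benzyl and cyclohexyl swaps in a cell cytotoxicity series

This account rests on a few compounds, and the source may have more. Where it says the series, first, only, none or still open, it means among the compounds named here.

Three compounds were measured in an ADME assay on HepG2 cells (Homo sapiens) for cytotoxicity, read by luminescence, CellTiter-Glo and ATP content, with a stated time of 72 h; a higher number here means that more compound is needed for the effect, a lower number that less compound is needed. Compound 1 `COc1ccc(F)cc1CNCCCNc1ccnc2cc(Cc3ccc(F)cc3Cl)ccc12` gives 2460 nM, compound 2 `COc1ccc(F)cc1CNCCCNc1ccnc2cc(CC3CCCCC3)ccc12` gives 1830 nM, and compound 3 `COc1cccc(CNCCCNc2ccnc3cc(CC4CCCCC4)ccc23)c1O` gives 970 nM. Compound 1 differs from compound 2 by 2-chloro-4-fluorophenyl in place of cyclohexyl on a saturated chain carbon bound to an aromatic carbon, a change that produced a 1.3-fold higher number from compound 2 to compound 1 (0.13 log units; within the scatter). The cores of compound 2 and compound 3 differ by 2-hydroxy-3-methoxyphenyl in place of 5-fluoro-2-methoxyphenyl on a saturated chain carbon bound to an amine nitrogen, and that change produced a 1.9-fold lower number from compound 2 to compound 3 (0.28 log units; within the scatter). Compound 4 `COc1cccc(CNCCCNc2ccnc3cc(Cc4ccc(F)cc4Cl)ccc23)c1O` has not yet been measured; it differs from compound 3 by 2-chloro-4-fluorophenyl in place of cyclohexyl on a saturated chain carbon bound to an aromatic carbon, the same change as from compound 2 to compound 1, at the same place. Because a 1.3-fold higher number from compound 2 to compound 1 (0.13 log units; within the scatter) stayed within the scatter, a step of similar size is expected for compound 4, namely a 1.3-fold higher number from compound 3 to compound 4 (0.13 log units; within the scatter). Compound 4 is therefore estimated at 1300 nM in this assay, with a plausible range from 600 nM to 3000 nM.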

Compound 4, half-maximal effective concentration: 2350 nM
Estimate against measurement, compound 4: 1.8-fold (0.26 log units) below; the range from low to high includes it.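

In this assay, 2-chloro-4-fluorophenyl in place of cyclohexyl gave a 2.4-fold higher number from compound 3 to compound 4 (0.38 log units; beyond the scatter), yet this step does not differ from its counterpart on the other core by more than the scatter allows: the same change on two cores in this assay, a 1.3-fold higher number (0.13 log units; within the scatter) from compound 2 to compound 1 and a 2.4-fold higher number (0.38 log units; beyond the scatter) from compound 3 to compound 4, 1.8-fold (0.26 log units) apart, within the scatter of two such steps. The exchange of 5-fluoro-2-methoxyphenyl for 2-hydroxy-3-methoxyphenyl gave a 1.0-fold lower number from compound 1 to compound 4 (0.02 log units; within the scatter), and it also agrees with its counterpart: the same change on two cores in this assay, a 1.9-fold lower number (0.28 log units; within the scatter) from compound 2 to compound 3 and a 1.0-fold lower number (0.02 log units; within the scatter) from compound 1 to compound 4, 1.8-fold (0.26 log units) apart, within the scatter of two such steps. Both changes therefore carried between these two cores without a detectable dependence on the core, but a single pair of steps per change does not show that the steps are equal or that they would hold on any other core.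

Going by these compounds, whether phenyl or cyclopentyl in place of cyclohexyl would follow the same pattern remains open. So does whether a longer chain on the amine nitrogen would leave these steps in this assay unchanged.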